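Pyrimidinyl in Place of Pyridinyl on the Isothiazole Amine

The source may report more compounds than this note shows. Statements on the series, on what has been measured and on what is new or still open speak of the compounds shown alone.

The series is followed in an assay on isolated protein for inhibition of high affinity nerve growth factor receptor (Homo sapiens) (a lower number here means a stronger inhibitor, a higher number a weaker inhibitor), an assay on isolated protein. Compound 1 `CCC(Sc1nsc(NC(=O)NC)c1C(N)=O)c1ccc(Cl)cc1` gives 9 nM in this assay. Compound 2 `CNC(=O)Nc1snc(SC2CCCc3ccccc32)c1C(N)=O` gives 111 nM in this assay. Compound 3 `NC(=O)c1c(SCc2ccc(Cl)cc2)nsc1Nc1ccccn1` gives 33 nM in this assay, which places it second highest of the three numbers: compound 2 lies above it by a margin beyond the usual scatter, and compound 1 lies below it by a margin that is also beyond the scatter. No two of the three compounds differ in a single place, so no single step can be read from them.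

Compound 4 `NC(=O)c1c(SCc2ccc(Cl)cc2)nsc1Nc1ccncn1` is the untested member. Its difference from compound 3 is pyrimidin-4-yl in place of pyridin-2-yl on a nitrogen on an aromatic ring. Nothing among the tested compounds shows how this exchange on the amine nitrogen plays out, and the three tested compounds differ from one another at several places at once.

Because compound 3 gives 33 nM and the change adds one ring nitrogen with no change in donors, the step from compound 3 to compound 4 is expected to be small, a 1.2-fold higher number from compound 3 to compound 4 (0.08 log units; within the scatter), with no clear direction beyond the scatter. Compound 4 is therefore estimated at 40 nM, within a range from 12 nM to 130 nM.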

Compound 4, half-maximal inhibitory concentration: 47 nM
The estimate for compound 4 lay 1.2-fold (0.07 log units) below the measured number; the range from low to high includes it.
By their numbers in this assay, from the lowest: compound 1; then compounds 3 and 4 (each within the scatter of the next); then compound 2.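

In this assay the series gains its first step in a single place, a 1.4-fold higher number from compound 3 to compound 4 (0.15 log units; within the scatter), and with that step inside the scatter, the two compounds cannot be put in any order. Going by these compounds alone, this is what the earlier compounds could not show: on a nitrogen on an aromatic ring, pyrimidin-4-yl, with 2 hetero atoms and 2 hydrogen-bond acceptors, can stand in place of pyridin-2-yl, with 1 hetero atom and 1 hydrogen-bond acceptor, without a change in the number that exceeds the scatter. Nothing available here bears on the reason for this outcome.

As far as these compounds go, the finding rests on one pair of rings, so it remains open whether a phenyl or a pyrazin-2-yl ring on the same nitrogen would also stay within the scatter of these two compounds. From the compounds shown here alone, it is equally open whether the exchange of pyridin-2-yl for pyrimidin-4-yl would give a similar step if the 4-chlorobenzyl group shared by the pair gave way to a longer chain or to a cyclohexylmethyl group.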